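Cytotoxicity of a biaryl amide hexanoate series

This account rests on a few compounds, and the source may have more. Where it says the series, first, only, none or still open, it means among the compounds named here.

Measured so far in an ADME assay on Raji cells (Homo sapiens) for cytotoxicity, read by CellTiter-Glo and resazurin assay, with a stated time of 72 h; a higher number here means that more compound is needed for the effect, a lower number that less compound is needed:
compound 1 `CC(=O)Nc1cccc(-c2ccc(C(=O)N(Cc3cccc(OCCCCCC(=O)O)c3)C(C)C)cc2)c1` gives > 26000 nM, a limit of the assay
compound 2 `CC(C)N(Cc1cccc(OCCCCCC(=O)O)c1)C(=O)c1ccc(-c2cccc(Br)c2)cc1` gives > 26000 nM, a limit of the assay
compound 3 `CCOC(=O)CCCCCOc1cccc(CN(C(=O)c2ccc(-c3cccc(NC(C)=O)c3)cc2)C(C)C)c1` gives > 26000 nM, a limit of the assay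

Compound 3 stands where every compound of the set stands so far, at the limit: the limit of > 26000 nM in this assay, at which 3 of the 3 values shown sit. Two single-point changes have been recorded, but neither has a readable size. The step that the two limits leave unreadable from compound 1 to compound 2 is unreadable because both ends sit at the limit (the limit of > 26000 nM in this assay, at which 3 of the 3 values shown sit). The step that the two limits leave unreadable from compound 1 to compound 3 is unreadable for the same reason, (the limit of > 26000 nM in this assay, at which 3 of the 3 values shown sit).

The next compound is compound 4 `CCOC(=O)CCCCCOc1cccc(CN(C(=O)c2ccc(-c3cc(OC)cc(OC)c3)cc2)C(C)C)c1`. Its change from compound 3 is 3,5-dimethoxyphenyl in place of 3-acetamidophenyl on an aromatic carbon. Among the compounds with values here, no measured step in this assay touches the 3,5-dimethoxyphenyl group, and the two steps recorded give no size at all, so there is nothing in the numbers to forecast a move in this assay in either direction. The set so far only says that none of the three compounds reaches a readable value.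

On that basis compound 4 is expected to behave like compound 3 and to give no readable value in this assay either; its estimate is 30000 nM, with a range from 10000 nM to 90000 nM. The expected step is a step that the limit leaves unreadable from compound 3 to compound 4, that is, no change that the assay could resolve.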

Compound 4, half-maximal effective concentration: > 26000 nM
Compound 4 gave a limit, no number; the forecaster's own chance of this, stated with the estimate: 80%; the middle value lies beyond the limit too.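

In this assay compound 4 gives > 26000 nM, a limit of the assay. The change from compound 3 to compound 4 cannot be read as a step, because both compounds sit at the same limit: the limit of > 26000 nM in this assay, at which 4 of the 4 values shown sit.

The compounds shown leave open which change to the shared core, if any, would give a readable value in this assay.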